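The compounds below may be only part of what the source reports. "The series", "measured", "known", "first", "only" and "open" are said of these compounds alone.

Compound 1 `CCCc1nc(-c2ccccc2)c(CNCCN2CCN(c3ccc(Cl)cc3)CC2)o1` gives 55.8% in an assay on HEK293 cells for inhibition of Voltage-dependent T-type calcium channel subunit alpha-1G (Homo sapiens), read by fluorescence, tested at 10 uM; a higher number here means more inhibition at the concentration tested (going by the name of the read-out), a lower number less inhibition.
Compound 2 `CCCc1nc(-c2ccccc2)c(CNCCN2CCN(c3ccccc3F)CC2)o1` gives 46.5% in this assay.
Compound 3 `CCCc1nc(-c2ccccc2)c(CNCCN2CCN(c3ccc(OC)cc3)CC2)o1` gives 51.5% in this assay.

Compound 3 stands second highest of these three numbers, but the gaps around it are small: the step of a number 4.3 percentage points lower from compound 1 to compound 3 (within the scatter) and the step of a number 5 percentage points higher from compound 2 to compound 3 (within the scatter) both stay within the scatter, so no real order among the three can be read off. The same holds for the step of a number 9.3 percentage points lower from compound 1 to compound 2 (within the scatter).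

Compound 4 `CCCc1nc(-c2ccccc2)c(CNCCN2CCN(c3ccc(C(F)(F)F)cc3)CC2)o1` is the next compound in this series. Compared with compound 3 it differs in one place: trifluoromethyl in place of methoxy on an aromatic carbon.

The measured steps that bear on this are those that changed the group on the same aromatic ring. The step of a number 4.3 percentage points lower from compound 1 to compound 3 (within the scatter) exchanged chloro for methoxy on an aromatic carbon without moving the number beyond the scatter, and the steps of a number 9.3 percentage points lower from compound 1 to compound 2 (within the scatter) and a number 5 percentage points higher from compound 2 to compound 3 (within the scatter), which changed the whole aryl group, were equally small. Three exchanges at this part of the molecule left the readout essentially unchanged, so the estimated step of a number 2.5 percentage points higher from compound 3 to compound 4 (within the scatter) is expected to stay within the scatter as well. Compound 4 is therefore estimated at 54%, with a likely range from 38% to 70%.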

Compound 4, a percentage reported as inhibition, at one concentration (the size of the read-out at that concentration, not a potency): 58.7%
The estimate for compound 4 lay 4.7 percentage points below the measured number; the range from low to high includes it.
By their numbers in this assay, from the lowest: compounds 2, 3, 1 and 4 (each within the scatter of the next, the first and the last beyond it).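

In this assay, trifluoromethyl on the aromatic carbon para to a large group reads much like the two groups already tried at that place: the exchange for methoxy gives a number 7.2 percentage points higher from compound 3 to compound 4 (within the scatter) and the exchange for chloro gives a number 2.9 percentage points higher from compound 1 to compound 4 (within the scatter). So three quite different groups at this carbon cannot be told apart by this measurement, which widens what the earlier pair showed. Within the data shown here, the new finding is the first gap to clear the scatter, a number 12.2 percentage points higher from compound 2 to compound 4 (beyond the scatter), although that step swaps 2-fluorophenyl for 4-(trifluoromethyl)phenyl, so the group and its place on the ring change together, and nothing available here gives a reason for the gap.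

The compounds shown cannot say whether the gap comes from the fluorine itself or from where a group sits on the ring, since no single step separates the two. They also leave open whether a group of a different kind at this carbon, such as an amine or a carboxylic acid, would read like these three in this assay or move the number beyond the scatter.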